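This account rests on a few compounds, and the source may have more. Where it says the series, first, only, none or still open, it means among the compounds named here.

In an ADME assay on BHK-21 cells (Mesocricetus auratus) for cytotoxicity, with a stated time of 3 days (on this read-out higher numbers stand for lower toxicity in this test and lower numbers for higher toxicity in this test), three compounds built on a shared core have been measured so far, and none of them has given a number. Compound 1 `CC(Sc1nnc(-c2ccncc2)s1)C(=O)Nc1ccccc1` is the plainest of the three. In this assay compound 1 gives > 50000 nM, which is a limit of the assay and not a number. Compound 2 `CC(Sc1nnc(-c2ccncc2)s1)C(=O)Nc1ccccc1Cl` differs from compound 1 by a chloro in place of hydrogen on an aromatic carbon. In this assay compound 2 gives > 50000 nM, again a limit. The step that the two limits leave unreadable from compound 1 to compound 2 therefore cannot be read. Within the data shown here, compound 3 `CC(CSc1nnc(-c2ccncc2)s1)C(=O)Nc1ccccc1Cl` carries a longer chain than compound 2; no step is computed for that pair, and the two values show only that both are limits. In this assay compound 3 gives > 50000 nM, so compound 3 stands exactly where compound 1 and compound 2 stand: the limit of > 50000 nM in this assay, at which 3 of the 3 values shown sit.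

Compound 4 `CC(CSc1nnc(-c2ccncc2)s1)C(=O)NCc1ccccc1Cl` differs from compound 3 in one place: 2-chlorobenzyl in place of 2-chlorophenyl on an amide-type nitrogen. Among the measured compounds shown here, no measured step bears on this change with a readable size, and the only computed step, a step that the two limits leave unreadable from compound 1 to compound 2, is itself unreadable. What the data offer is the limit of > 50000 nM in this assay, at which 3 of the 3 values shown sit, which points to a value again at the limit. The expected step is a step that the limit leaves unreadable from compound 3 to compound 4, nothing beyond the scatter. Compound 4 is therefore estimated at 80000 nM, with a range from 40000 nM to 200000 nM.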

Compound 4, half-maximal cytotoxic concentration: > 50000 nM
Compound 4: only a limit was reported; the forecaster's own chance of this, stated with the estimate: 85%; the middle value lies beyond the limit too.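

In this assay compound 4 gives > 50000 nM, which is a limit and not a number. Compound 3 also sits at a limit, so no size can be read for the step between compound 3 and compound 4. The compounds shown leave open what number any of them would reach in this assay, and which change, if any, would shift it.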